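Nitro in Place of Hydrogen on the Aromatic Ring

This account rests on a few compounds, and the source may have more. Where it says the series, first, only, none or still open, it means among the compounds named here.

Among the compounds with values here, compound 1 `CC1=CC[C@H](C(C)(C)NC(=S)N/N=C/c2ccccc2)CC1` gives 1300 nM in a functional assay on PC-3 cells (Homo sapiens) for inhibition, read by sulforhodamine B assay, with a stated time of 48 h (on this read-out higher numbers stand for weaker inhibition of growth and lower numbers for stronger inhibition of growth), the highest of the two numbers measured so far. Compound 2 `CC1=CC[C@H](C(C)(C)NC(=S)N/N=C/c2ccccc2Cl)CC1` gives 50 nM in this assay, and the step of a 26-fold lower number from compound 1 to compound 2 (1.41 log units; beyond the scatter) came from chloro in place of hydrogen on an aromatic carbon. Compound 3 `CC1=CC[C@H](C(C)(C)NC(=S)N/N=C/c2cccc([N+](=O)[O-])c2)CC1` differs from compound 1 by nitro in place of hydrogen on an aromatic carbon. Within the data shown here, only that one step bears on this change, and it was large, so a lower number is expected for compound 3, though the entering group differs and the size is uncertain. The estimate for compound 3 is 300 nM, between 60 nM and 1500 nM, a step of a 4.3-fold lower number from compound 1 to compound 3 (0.64 log units; beyond the scatter).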

Compound 3, concentration for 50% growth inhibition: 9500 nM
Compound 3: the middle estimate sits 32-fold (1.50 log units) below what was measured, and the stated range ends below it.
By their numbers in this assay, from the lowest: compound 2; then compound 1; then compound 3.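

Putting a group on the aromatic ring does not always give stronger growth inhibition in this assay: nitro meta to a large group gives a 7.3-fold higher number from compound 1 to compound 3 (0.86 log units; beyond the scatter) and so runs against a 26-fold lower number from compound 1 to compound 2 (1.41 log units; beyond the scatter) in direction. The earlier chloro step therefore does not carry over to every group on this ring. Nothing available here explains this difference in direction.

Going by these compounds, whether the higher number belongs to the nitro group itself or to its place on the ring stays open. Also open, on these data alone, is how an amine or a methoxy group would behave on the same aromatic carbon.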